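A few compounds are considered here, and "the series" means these few. Any claim that something is new, unique, unknown or untested is made for them only; others in the source may bear on it.

In a functional assay on SMMC-7721 cells (Homo sapiens) for cytotoxicity, read by MTT assay, with a stated time of 24 h (a higher number here means a weaker inhibitor, a lower number a stronger inhibitor), compound 3 `CCOC(=O)c1sc(-c2nc3ccccc3n2Cc2ccccc2)nc1C` gives 2780 nM, the lowest of the two numbers measured. Compound 1 `CCOC(=O)c1sc(-c2nc3ccccc3n2C)nc1C` gives 13900 nM, giving a 5.0-fold lower number from compound 1 to compound 3 (0.70 log units; beyond the scatter). Compound 2 `CCOC(=O)c1sc(-c2nc3ccccc3n2C(C)C)nc1C` reaches only the limit of the assay, > 20000 nM, as recorded in the limit of > 20000 nM in this assay, at which 1 of the 3 values shown sits. Compound 4 `Cc1nc(-c2nc3ccccc3n2Cc2ccccc2)sc1C(=O)N1CCCCC1` differs from compound 3 by piperidin-1-yl in place of ethoxy on a carbonyl carbon. Going by the values given here, the measured steps, an at least 1.4-fold higher number from compound 1 to compound 2 (0.15 log units; that floor lies within the scatter), a 5.0-fold lower number from compound 1 to compound 3 (0.70 log units; beyond the scatter) and an at least 7.1-fold lower number from compound 2 to compound 3 (0.85 log units; beyond the scatter), all concern the substituent on the aromatic nitrogen; no measured step touches the carbonyl carbon, so they bear on this change only indirectly and give no direction for it. For compound 4 the expected value is 3000 nM, between 1000 nM and 9000 nM. The step of a 1.1-fold higher number from compound 3 to compound 4 (0.03 log units; within the scatter) is therefore expected to fall within the scatter.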

Compound 4, half-maximal inhibitory concentration: > 20000 nM
Compound 4: a limit, no number (the forecaster's own chance of this, stated with the estimate: 5%); at least 6.6-fold (0.82 log units) between middle value and limit.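

Going by these compounds alone, the carbonyl carbon is the first place varied outside the substituent on the aromatic nitrogen, and the series is not indifferent to it: in this assay the step ethoxycarbonyl to (piperidin-1-yl)carbonyl gives an at least 7.1-fold higher number from compound 3 to compound 4 (0.85 log units; beyond the scatter) with the benzyl group held. The benzyl group alone does not keep the activity of compound 3. The size of this step is only a floor, as compound 4 reads as a limit and not a number: the limit of > 20000 nM in this assay, at which 2 of the 4 values shown sit.

Going by these compounds, whether the loss follows from the amide link or from the piperidine ring stays open. A dimethylamide, a morpholine amide or a carboxylic acid on the same carbonyl carbon would separate the two.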